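The source may hold more compounds than are shown below. What is called first, only, known or untested is meant among the compounds shown, and "the series" means these compounds.

Of the compounds shown here, three built on one shared core have been tested in an assay on HEK293 cells for inhibition of Voltage-dependent T-type calcium channel subunit alpha-1G (Homo sapiens), read by fluorescence, tested at 10 uM; on this read-out higher numbers stand for more inhibition at the one concentration tested (going by the name of the read-out) and lower numbers for less inhibition. Compound 1 `CCCc1nc(-c2ccccc2)c(CNCCCN2CCN(c3ccc(F)cc3)CC2)o1` gives 62.5%. Compound 2 `CCCc1nc(-c2ccccc2)c(CNCCN2CCN(c3cccc(Cl)c3)CC2)o1` gives 51.2%, and compound 3 `CCCc1nc(-c2ccccc2)c(CNCCN2CCN(c3ccc(OC)cc3)CC2)o1` gives 51.5%. Compound 1 thus stands highest of the three, with the nearest number, that of compound 3, lying beyond the scatter below it. Compound 4 `CCCc1nc(-c2ccccc2)c(CNCCCN2CCN(c3ccc(C)c(C)c3)CC2)o1` differs from compound 1 in one place: 3,4-dimethylphenyl in place of 4-fluorophenyl on an amine nitrogen in a ring. For the measured compounds named here, the only measured step that touches the same place, a number 0.3 percentage points higher from compound 2 to compound 3 (within the scatter), stayed within the scatter. Swapping one aromatic ring for another on the amine nitrogen in the ring is therefore expected to change the read-out little, so the expected step is a number 4.5 percentage points lower from compound 1 to compound 4 (within the scatter). Compound 4 is accordingly estimated at 58%, with a range from 40% to 75%.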

Compound 4, a percentage reported as inhibition, at one concentration (the size of the read-out at that concentration, not a potency): 54.6%
The estimate for compound 4 lay 3.4 percentage points above the measured number, and the stated range covers the measured number.
By their numbers in this assay, from the lowest: compounds 2, 3, 4 and 1 (each within the scatter of the next, the first and the last beyond it).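

For the compounds shown here, with a number 7.9 percentage points lower from compound 1 to compound 4 (within the scatter), a second swap of one substituted phenyl ring for another on the amine nitrogen in the ring stays within the usual scatter, this time starting from compound 1, the compound with the highest number so far. Two pairs of compounds now show this, but they cover only substituted phenyl groups at this position. Nothing available explains why the number holds up across this change. Still open, going by these compounds, is what happens when a group other than a substituted phenyl ring, such as a pyridyl, benzyl or acetyl group, sits on that nitrogen.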